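Extending the ethoxy chain of compound 3

The source may hold more compounds than are shown below. What is called first, only, known or untested is meant among the compounds shown, and "the series" means these compounds.

In a functional assay on the whole organism (strain Sprague-Dawley) for inhibition, with Rattus norvegicus as the target, with a stated time of 10 min (a higher number here means that more compound is needed for the effect, a lower number that less compound is needed), compound 3 `CCOc1ccccc1-c1ncc(C(=O)O)c(=O)[nH]1` stands lowest at 0.5 mg/kg while compound 1 `O=C(O)c1cnc(-c2ccccc2)[nH]c1=O` gives 50 mg/kg and compound 2 `Nc1ccccc1-c1ncc(C(=O)O)c(=O)[nH]1` gives 50 mg/kg on the same read-out. Ethoxy in place of hydrogen gave a 100-fold lower number from compound 1 to compound 3 (2.00 log units; beyond the scatter) and ethoxy in place of amino gave a 100-fold lower number from compound 2 to compound 3 (2.00 log units; beyond the scatter) whereas amino in place of hydrogen gave no change at the digits printed from compound 1 to compound 2 (within the scatter) in this series. Compound 4 `CC(C)COc1ccccc1-c1ncc(C(=O)O)c(=O)[nH]1` turns ethoxy into isobutoxy with isopropyl in place of methyl on a saturated chain carbon bound to an oxygen on an aromatic ring as the counted difference. Among the measured compounds shown here, no measured step alters the ethoxy chain itself, so those large steps set no size here. A small upward shift is expected, namely a 1.6-fold higher number from compound 3 to compound 4 (0.20 log units; within the scatter) as estimated. The estimate for compound 4 is 0.8 mg/kg (expected range 0.15 mg/kg to 4 mg/kg).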

Compound 4, dose for 50% inhibition: 0.5 mg/kg
Compound 4: the middle estimate sits 1.6-fold (0.20 log units) above what was measured; the measured number falls inside the stated range.
By their numbers in this assay, from the lowest: compounds 3 and 4 (each within the scatter of the next); then compounds 1 and 2 (each within the scatter of the next).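

In this assay, among the compounds shown here, the ethoxy chain is altered for the first time: isopropyl in place of methyl on a saturated chain carbon bound to an oxygen on an aromatic ring gives no change at the digits printed from compound 3 to compound 4 (within the scatter), so ethyl to isobutyl leaves the number in place. Isobutoxy carries the same large steps as ethoxy, with a 100-fold lower number from compound 2 to compound 4 (2.00 log units; beyond the scatter) and a 100-fold lower number from compound 1 to compound 4 (2.00 log units; beyond the scatter) on the same read-out. No supporting evidence bears on this result.

Open, as far as these compounds go, is whether methoxy or a longer straight chain such as hexyloxy would hold the number. Also open, from the compounds shown here alone, is how a chain ending in an amine or a carboxylic acid would read.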